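A few compounds are considered here, and "the series" means these few. Any claim that something is new, unique, unknown or untested is made for them only; others in the source may bear on it.

Measured so far:
Compound 1 `Cc1c(C)c2ccc(OCCCCCN(C)Cc3cccc(C#N)c3)cc2oc1=O`: 2500 nM
Compound 2 `CN(C)Cc1ccc(COc2ccc3ccc(=O)oc3c2)cc1`: 3700 nM

Both were tested in an assay for inhibition of Amine oxidase [flavin-containing] B (Rattus norvegicus), read by spectrophotometry; a higher number here means a weaker inhibitor, a lower number a stronger inhibitor. Compound 2 shows the numerically higher of the two numbers, but its gap to compound 1 lies within the scatter, so the two compounds are not separated by these data.

Compound 3 `CN(Cc1ccc(COc2ccc3ccc(=O)oc3c2)cc1)Cc1cccc(C#N)c1` differs from compound 2 in one place: 3-cyanophenyl in place of hydrogen on a saturated chain carbon bound to an amine nitrogen. Within the data shown here, no measured pair shows this exact change, so any expectation rests on what is known. Compound 1 carries the same 3-cyanobenzyl group on its amine nitrogen and gives 2500 nM in this assay, a number close to that of compound 2. The step is therefore expected to be small, toward a lower number, and possibly not beyond the scatter; the expected step is a 2.5-fold lower number from compound 2 to compound 3 (0.39 log units; beyond the scatter). Compound 3 is estimated at 1500 nM, with a range from 400 nM to 6000 nM.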

Compound 3, half-maximal inhibitory concentration: 2800 nM
Estimate against measurement, compound 3: 1.9-fold (0.27 log units) below, within the range that was stated.
By their numbers in this assay, from the lowest: compounds 1, 3 and 2 (each within the scatter of the next).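

In this assay the change of methyl to 3-cyanobenzyl on the amine nitrogen gives a 1.3-fold lower number from compound 2 to compound 3 (0.12 log units; within the scatter) and so leaves the two compounds unseparated. Among these compounds, this matched pair, which the earlier compounds did not provide, shows that this nitrogen can carry a much larger group, with an added aromatic ring and nitrile, without a measurable shift in either direction. No supporting measurement bears on why the number holds steady across so large a change.

As far as these compounds go, a plain benzyl group on the same nitrogen would show whether the nitrile contributes anything on its own, and this remains open. Also open, from the compounds shown here alone, is how an amine nitrogen bearing hydrogen in place of the methyl, or a longer chain ending in a carboxylic acid, would read in this position.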